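The compounds below may be only part of what the source reports. "The series", "measured", "known", "first", "only" and "open" are said of these compounds alone.

Among the measured compounds shown here, only two compounds have numbers so far in a functional assay on microsomes for inhibition, with a stated time of 1 h; on this read-out higher numbers stand for weaker inhibition and lower numbers for stronger inhibition. Compound 1 `CCOC(=O)c1cnn(-c2nc(-c3cccc(OC)c3OC)c(C#N)c(=O)n2C)c1N` gives 57 ug/mL, and compound 2 `CN(C)c1ccc(-c2nc(NN)n(C)c(=O)c2C#N)cc1` gives 63 ug/mL. These two values lie within the usual scatter of repeated measurements, so compound 1 sits level with compound 2 and neither can be called the better inhibitor. The compound waiting to be measured, compound 3 `CCOC(=O)c1cnn(-c2nc(-c3cccs3)c(C#N)c(=O)n2C)c1N`, keeps the core of compound 1 and exchanges a single group: thiophen-2-yl in place of 2,3-dimethoxyphenyl on an aromatic carbon, ortho to a cyano group. Counted atom by atom, the change is thiophen-2-yl in place of 2,3-dimethoxyphenyl on an aromatic carbon. For the measured compounds named here, no pair of measured compounds shows what an exchange like this does in this assay, so the data offer no guide to its size or direction. The working expectation is therefore no change beyond the scatter, with neither direction favoured, and a wide range to reflect how little is known. The expected result is a 1.0-fold lower number from compound 1 to compound 3 (0.02 log units; within the scatter). For compound 3 the estimated value is 55 ug/mL, with an expected range from 22 ug/mL to 130 ug/mL.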

Compound 3, half-maximal inhibitory concentration: 97 ug/mL
The estimate for compound 3 lay 1.8-fold (0.25 log units) below the measured number; measured number inside the range.
By their numbers in this assay, from the lowest: compounds 1, 2 and 3 (each within the scatter of the next).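

At the aromatic carbon ortho to a cyano group, thiophen-2-yl in place of 2,3-dimethoxyphenyl gives a 1.7-fold higher number from compound 1 to compound 3 (0.23 log units; within the scatter) in this assay, and this is the only step shown so far at this position. It shows that a group of 5 heavy atoms, a five-membered aromatic ring with sulfur as its hetero atom, can stand where a group of 10 heavy atoms with 2 oxygen atoms stood, without a difference that rises clearly above the scatter of the assay. Nothing available bears on why the two compounds read as they do, so the step can be reported but not explained.

From the compounds shown here alone, a single exchange cannot show how much this position responds to change in general, so it remains open whether a plain phenyl, a pyridine, or a group of another kind, such as an amine or a carboxylic acid on this carbon, would give a difference beyond the scatter. Going by these compounds, the shared parts of compound 1 and compound 3 also remain untested here, including whether a carboxylic acid in place of the ethyl ester would alter the number.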